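A few compounds are considered here, and "the series" means these few. Any claim that something is new, unique, unknown or untested is made for them only; others in the source may bear on it.

Compound 1, `C#CCN1CCN(CC(=O)N2CCN(c3ccc(C(=O)c4cc5ccc(N(CC)CC)cc5o4)cc3)CC2)CC1`, in a functional assay on HCT-116 cells (Homo sapiens) for cytotoxicity, read by MTT assay, with a stated time of 48 h (a higher number here means a weaker inhibitor, a lower number a stronger inhibitor), gives 17700 nM.
Compound 2, `CCN(CC)c1ccc2cc(C(=O)c3ccc(N4CCN(C(=O)CN5CCN(Cc6ccc(F)c(F)c6)CC5)CC4)cc3)oc2c1`, in this assay gives 26300 nM.

Among these two measured compounds, compound 2 gives the highest number, but its nearest neighbour, compound 1, sits within the usual scatter of it, so no real difference between the two has been shown. Compound 3, `CCN(CC)c1ccc2cc(C(=O)c3ccc(N4CCN(C(=O)CN5CCN(Cc6ccc(C#N)cc6)CC5)CC4)cc3)oc2c1`, is not yet measured. It differs from compound 2 in one place: 4-cyanophenyl in place of 3,4-difluorophenyl on a saturated chain carbon bound to an amine nitrogen in a ring. Among the compounds with values here, the only measured step that bears on this position is a 1.5-fold higher number from compound 1 to compound 2 (0.17 log units; within the scatter), which exchanged a small group for an aromatic ring at the same place without moving the number beyond the scatter. Exchanging one aromatic ring for another at that place is therefore expected to give a 1.2-fold lower number from compound 2 to compound 3 (0.08 log units; within the scatter), that is, no clear change in this assay in either direction. Compound 3 is estimated to give 22000 nM, with a likely range from 9000 nM to 55000 nM.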

Compound 3, half-maximal inhibitory concentration: > 40000 nM
Compound 3 gave a limit, no number; the forecaster's own chance of this, stated with the estimate: 10%; middle value at least 1.8-fold (0.25 log units) from the limit.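

In this assay compound 3 gives only a limit of the assay, not a number: the limit of > 40000 nM in this assay, at which 1 of the 3 values shown sits.

The exchange of 3,4-difluorophenyl for 4-cyanophenyl gives an at least 1.5-fold higher number from compound 2 to compound 3 (0.18 log units; that floor lies within the scatter), so this floor alone does not separate the two rings. Within the data shown here, the exchange of ethynyl for 4-cyanophenyl gives an at least 2.2-fold higher number from compound 1 to compound 3 (0.35 log units; beyond the scatter), the first step at this place to pass the scatter, whereas a 1.5-fold higher number from compound 1 to compound 2 (0.17 log units; within the scatter) did not, so the group on this saturated chain carbon can change the number.

On these data alone, how far compound 3 lies past its limit stays open, and with it the full size of both steps. Also open, as far as these compounds go, is how a plain phenyl, or a phenyl carrying an amine or a carboxylic acid, would read at the same place.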